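A few compounds are considered here, and "the series" means these few. Any claim that something is new, unique, unknown or untested is made for them only; others in the source may bear on it.

For the measured compounds named here, compound 3 `CC(C)Nc1sc(C(=O)c2ccc(Cl)s2)c(N)c1C#N` is the one member of this set with a number rather than a limit: in an assay for inhibition of Maternal embryonic leucine zipper kinase (Homo sapiens), read by ADP-Glo, with a stated time of 0.5 h (on this read-out lower numbers stand for stronger inhibition and higher numbers for weaker inhibition), compound 3 gives 192 nM. Compound 1 `CC(=O)c1sc(NC(C)C)c(C#N)c1N` reaches only a limit of the assay, giving > 5000 nM in this assay. Compound 2 `CC(C)Nc1sc(C(=O)c2cccnc2)c(N)c1C#N` likewise reaches only a limit, giving > 5000 nM in this assay. Because (the limit of > 5000 nM in this assay, at which 2 of the 3 values shown sit), the step that the two limits leave unreadable from compound 1 to compound 2 cannot be read. The steps of an at least 26-fold lower number from compound 1 to compound 3 (1.41 log units; beyond the scatter) and an at least 26-fold lower number from compound 2 to compound 3 (1.41 log units; beyond the scatter) are large. Compound 4 `CC(C)Nc1sc(C(=O)c2ccc(Br)s2)c(N)c1C#N` differs from compound 3 in one place: bromo in place of chloro on an aromatic carbon. Going by the values given here, none of the measured steps exchanges one halogen for another on that ring; all three turn on the group on the carbonyl carbon, which is kept here, so none bears directly on this step. The expected step of a 1.0-fold lower number from compound 3 to compound 4 (0.00 log units; within the scatter) is therefore none beyond the scatter. Compound 4 is estimated to give 190 nM in this assay, within 80 nM to 450 nM.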

Compound 4, half-maximal inhibitory concentration: 122 nM
The estimate for compound 4 lay 1.6-fold (0.19 log units) above the measured number; the measured number falls inside the stated range.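

In this assay, the step of a 1.6-fold lower number from compound 3 to compound 4 (0.20 log units; within the scatter) stays within the scatter, so at this position on the thiophene ring, next to the ring sulfur, chloro and bromo cannot be told apart. The large steps seen earlier with 5-chlorothiophen-2-yl on the carbonyl carbon are therefore not tied to chlorine: 5-bromothiophen-2-yl gives an at least 40-fold lower number from compound 2 to compound 4 (1.61 log units; beyond the scatter) and an at least 40-fold lower number from compound 1 to compound 4 (1.61 log units; beyond the scatter). Both of these steps are open-ended, since each starts from a limit of the assay rather than a number.

The compounds shown leave open whether a halogen is needed here at all, and what a hydrogen, a methyl group or a methoxy group at this position would give. The step between compound 1 and compound 2 still cannot be read: the limit of > 5000 nM in this assay, at which 2 of the 4 values shown sit.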